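This account rests on a few compounds, and the source may have more. Where it says the series, first, only, none or still open, it means among the compounds named here.

Compound 1 `C[C@H](CC1CCCCC1)NC(=S)Nc1ccc(F)c(Cl)c1`: 15100 nM
Compound 2 `CC[C@H](Nc1nc2cc(Cl)c(F)cc2s1)c1ccccc1`: 32200 nM
Compound 3 `Fc1ccc(NC(=S)NC2CCCCC2OCc2ccccc2)cc1Cl`: 10600 nM

In a functional assay on Ehrlich cells (Mus musculus) for cytotoxicity, read by MTT assay, with a stated time of 24 h (a higher number here means a weaker inhibitor, a lower number a stronger inhibitor), compound 1 gives 15100 nM, the second highest of the three numbers. Compound 3, at 10600 nM, sits within the scatter of compound 1, so the two cannot be told apart. Compound 2, at 32200 nM, lies beyond the scatter above compound 1. The unmeasured compound 4 `CCCCCC[C@@H](C)NC(=S)Nc1ccc(F)c(Cl)c1` differs from compound 1 by pentyl in place of cyclohexyl on a saturated chain carbon, two bonds along the chain from an amide-type nitrogen. Among the compounds with values here, no measured pair shows this change, so its effect is unknown; with such a modest change, the step from compound 1 is expected to be small, at most a slight rise in the number, likely within the scatter. Compound 4 is therefore expected to give about 18000 nM, between 7000 nM and 45000 nM, a step of a 1.2-fold higher number from compound 1 to compound 4 (0.08 log units; within the scatter).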

Compound 4, half-maximal inhibitory concentration: 25500 nM
The estimate for compound 4 lay 1.4-fold (0.15 log units) below the measured number, and the stated range covers the measured number.
By their numbers in this assay, from the lowest: compounds 3, 1, 4 and 2 (each within the scatter of the next, the first and the last beyond it).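

In this assay, pentyl in place of cyclohexyl on a saturated chain carbon, two bonds along the chain from an amide-type nitrogen, gives a 1.7-fold higher number from compound 1 to compound 4 (0.23 log units; within the scatter). At this position, then, an open chain and the ring cannot be told apart, although this rests on a single pair. Nothing at hand explains the result. As far as these compounds go, whether a longer chain, a phenyl ring or a terminal amine at this position would give a step beyond the scatter remains open, as does whether the same change would read alike on another core.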